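Removing trifluoromethyl from compound 2

A few compounds are considered here, and "the series" means these few. Any claim that something is new, unique, unknown or untested is made for them only; others in the source may bear on it.

Compound 1 `COc1cc(-c2nn(-c3cccc(NC(=O)Nc4cc(C(F)(F)F)cc(C(F)(F)F)c4)c3)cc2-c2ccncc2)ccc1Cl` gives 1090 nM
Compound 2 `COc1cc(-c2nn(-c3cccc(NC(=O)c4cccc(C(F)(F)F)c4)c3)cc2-c2ccncc2)ccc1Cl` gives 1560 nM

Among the compounds with values here, in a functional assay on NCI-H23 cells (Homo sapiens) for inhibition, read by sulforhodamine B assay, with a stated time of 48 h (on this read-out higher numbers stand for weaker inhibition of growth and lower numbers for stronger inhibition of growth), compound 2 at 1560 nM lies within the usual scatter of compound 1 at 1090 nM, so the two numbers set no order between these compounds. Within the data shown here, they differ in more than one place, and no single-place step has been measured.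

The next compound to be tested is compound 3 `COc1cc(-c2nn(-c3cccc(NC(=O)c4ccccc4)c3)cc2-c2ccncc2)ccc1Cl`. Its structure departs from compound 2 by one change: hydrogen in place of trifluoromethyl on an aromatic carbon. In words, hydrogen stands in place of trifluoromethyl on an aromatic carbon, meta to a large group, and 3-(trifluoromethyl)phenyl becomes phenyl.

Compound 1 and compound 2 both carry trifluoromethyl, whereas compound 3 has none, so no measured number shows how the series behaves without this group. A small step towards a higher number in this assay, meaning weaker inhibition of growth, is expected, near the edge of the scatter and with a real chance of none. The estimated change is a 1.9-fold higher number from compound 2 to compound 3 (0.28 log units; within the scatter). The estimated value for compound 3 is 3000 nM, with an expected range of 1200 nM to 7500 nM.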

Compound 3, concentration for 50% growth inhibition: 2020 nM
Estimate against measurement, compound 3: 1.5-fold (0.17 log units) above; low and high end bracket the measured number.
By their numbers in this assay, from the lowest: compounds 1, 2 and 3 (each within the scatter of the next).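

In this assay hydrogen in place of trifluoromethyl on this aromatic carbon, which turns 3-(trifluoromethyl)phenyl into phenyl, reads as a 1.3-fold higher number from compound 2 to compound 3 (0.11 log units; within the scatter) and sets no order between the two compounds. This is the first single-place step in the series, and it shows that the loss of 4 heavy atoms at this position, leaving plain benzoyl in place of (3-(trifluoromethyl)phenyl)carbonyl, gives no readable shift in growth inhibition, so trifluoromethyl is not shown to be needed here for a number in this range. No measurement at hand offers an explanation for this result.

The compounds shown leave open whether a different group on this aromatic carbon, such as an amine, a carboxylic acid or a longer alkyl chain, would move the number beyond the scatter. Within the data shown here, they also leave open whether the same replacement of trifluoromethyl would read alike on the 3,5-bis(trifluoromethyl)phenyl urea of compound 1, where no single-place step is yet available.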